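Methyl Ether for Acetate on Two Related Terpenoid Scaffolds

This account rests on a few compounds, and the source may have more. Where it says the series, first, only, none or still open, it means among the compounds named here.

Of the compounds shown here, three have been tested in a functional assay on A549 cells (Homo sapiens) for antiproliferative activity, read by MTT assay, with a stated time of 48 h; a lower number here means a stronger inhibitor, a higher number a weaker inhibitor. Compound 1, `CC(=O)OC/C1=C/C[C@](C)(CCC=C(C)C)/C=C/[C@@H](OC(=O)C=C(C)C)[C@](C)(O)/C=C/C1=O`, gives 2950 nM. Compound 2, `COC/C1=C/C[C@](C)(CCC=C(C)C)/C=C/[C@@H](OC(=O)C=C(C)C)[C@](C)(O)/C=C/C1=O`, carries a methyl ether where compound 1 carries an acetate; in this assay compound 2 gives 3950 nM. The change between them is methyl in place of acetyl on an oxygen on a saturated carbon and its size is a 1.3-fold higher number from compound 1 to compound 2 (0.13 log units; within the scatter), so the two numbers cannot be told apart with confidence.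

Compound 3, `CC(=O)O[C@]1(C)/C=C/C(=O)/C(CO)=C\C[C@](C)(CCC=C(C)C)/C=C/[C@H]1OC(=O)C=C(C)C`, is built from the same atoms as compound 1, joined differently; the difference between the two cores is not broken down here. In this assay compound 3 gives 3150 nM, which sits close to the numbers of compound 1 and compound 2, all within the usual scatter of one another.

Compound 4, `CO[C@]1(C)/C=C/C(=O)/C(CO)=C\C[C@](C)(CCC=C(C)C)/C=C/[C@H]1OC(=O)C=C(C)C`, has not yet been measured. It differs from compound 3 by methyl in place of acetyl on an oxygen on a saturated carbon. This is the same kind of change as that from compound 1 to compound 2, but the surroundings are not identical: in compound 1 the saturated carbon bearing the oxygen has a saturated chain carbon as its other neighbour, whereas in compound 3 it has a saturated ring carbon.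

Within the data shown here, since the only example of this change, from compound 1 to compound 2, stayed within the scatter, compound 4 is expected to land near compound 3, with an expected step of a 1.3-fold higher number from compound 3 to compound 4 (0.10 log units; within the scatter). The estimate for compound 4 is 4000 nM, expected to fall between 2000 nM and 8500 nM.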

Compound 4, half-maximal inhibitory concentration: 14400 nM
Beside the measured number, compound 4's estimate is 3.6-fold (0.56 log units) below it; the whole stated range lies below it.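

In this assay, replacing acetoxy with methoxy on the core of compound 3 gives a 4.6-fold higher number from compound 3 to compound 4 (0.66 log units; beyond the scatter), a weakening that the same change did not produce in a readable way on the core of compound 1. The result shows that, in this series, the size of this change did not carry over from one core to the other, so a step measured on one core was a poor guide to the step on the other: the same change on two cores in this assay, a 1.3-fold higher number (0.13 log units; within the scatter) from compound 1 to compound 2 and a 4.6-fold higher number (0.66 log units; beyond the scatter) from compound 3 to compound 4, 3.4-fold (0.53 log units) apart, beyond the scatter of two such steps. Among these compounds, it does not show why the two cores respond differently, and with only one pair of compounds on each core, it sets no rule for how the change would behave on any further core.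

The compounds shown leave open how other groups on the same oxygen would behave on these two cores, for example an ethyl group in place of the methyl, or a propanoyl group in place of the acetyl. They also leave open whether the gap between the two cores depends on the methyl group alone, and whether it would appear in cell lines other than the one tested here.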